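A few compounds are considered here, and "the series" means these few. Any claim that something is new, unique, unknown or untested is made for them only; others in the source may bear on it.

Three amides sharing one core have been measured in an assay on HEK293 cells for displacement of a labelled ligand from metabotropic glutamate receptor 5 (Rattus norvegicus); a higher number here means a weaker inhibitor, a lower number a stronger inhibitor. Compound 1 `Cc1ccc(C(=O)Nc2cc(-c3ccccc3)nn2-c2ccccc2)cc1` gives 780 nM in this assay. Compound 2 `O=C(Nc1cc(-c2ccccc2)nn1-c1ccccc1)c1ccc(C(F)(F)F)cc1` gives 990 nM. Compound 3 `O=C(Nc1cc(-c2ccccc2)nn1-c1ccccc1)c1ccc([N+](=O)[O-])cc1` gives 250 nM, the lowest number of the three, so it is the strongest inhibitor among them: the steps are a 3.1-fold lower number from compound 1 to compound 3 (0.49 log units; beyond the scatter) and a 4.0-fold lower number from compound 2 to compound 3 (0.60 log units; beyond the scatter), both beyond the scatter. By contrast the step of a 1.3-fold higher number from compound 1 to compound 2 (0.10 log units; within the scatter) lies within the scatter.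

Compound 4 `Cc1ccc(C(=O)Nc2cc(-c3ccccc3)nn2-c2ccccc2)cc1C` has not yet been measured. The change from compound 3 is 3,4-dimethylphenyl in place of 4-nitrophenyl on a carbonyl carbon. Going by the values given here, two measured steps bear on it: the change from methyl to nitro gave a 3.1-fold lower number from compound 1 to compound 3 (0.49 log units; beyond the scatter), and from trifluoromethyl to nitro gave a 4.0-fold lower number from compound 2 to compound 3 (0.60 log units; beyond the scatter). Compound 4 reverses the nitro-to-methyl direction and carries one further methyl, for which no measured comparison exists. The expectation is therefore that the number rises back to about the level of compound 1, an estimated step of a 3.2-fold higher number from compound 3 to compound 4 (0.51 log units; beyond the scatter). The estimated value for compound 4 in this assay is 800 nM, with an expected range from 300 nM to 2200 nM.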

Compound 4, inhibition constant: 430 nM
Beside the measured number, compound 4's estimate is 1.9-fold (0.27 log units) above it; low and high end bracket the measured number.
By their numbers in this assay, from the lowest: compounds 3, 4, 1 and 2 (each within the scatter of the next, the first and the last beyond it).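

Adding one further methyl on an aromatic carbon to compound 1 gives compound 4 and moves the result in this assay by no more than the usual scatter (a 1.8-fold lower number from compound 1 to compound 4 (0.26 log units; within the scatter)), so this second methyl can be accommodated without a clear gain or loss. Compound 3 no longer stands apart from every other compound: the 3,4-dimethylphenyl group, which has no hydrogen-bond acceptors, lies within the scatter of the 4-nitrophenyl group, which has two (a 1.7-fold higher number from compound 3 to compound 4 (0.24 log units; within the scatter)), so hydrogen-bond acceptors on this ring are not needed to reach that range. The 4-(trifluoromethyl)phenyl group remains separated from the 3,4-dimethylphenyl group by more than the scatter (a 2.3-fold lower number from compound 2 to compound 4 (0.36 log units; beyond the scatter)), and no measurement is available to explain any of these steps.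

From the compounds shown here alone, with only these four compounds, it remains open how a methoxy group, a chlorine atom or an amine on this ring would compare with methyl and nitro. The compounds also leave open whether a single methyl placed elsewhere on the ring, or a longer chain such as ethyl or propyl, would move the number beyond the scatter.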